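Acyl chain changes in the shared amide series

This account rests on a few compounds, and the source may have more. Where it says the series, first, only, none or still open, it means among the compounds named here.

Compound 1 `CCCCC(=O)N(Cc1ccc(OC)c(O)c1)c1cc(OC)c(OC)c(OC)c1`: 170 nM
Compound 2 `COc1ccc(CN(C(=O)CO)c2cc(OC)c(OC)c(OC)c2)cc1O`: 520 nM
Compound 3 `CCC(=O)N(Cc1ccc(OC)c(O)c1)c1cc(OC)c(OC)c(OC)c1`: 61 nM

All three were measured in a functional assay on HCT-116 cells (Homo sapiens) for inhibition, read by MTT assay, with a stated time of 48 h; on this read-out higher numbers stand for weaker inhibition and lower numbers for stronger inhibition. Compound 3 gives the lowest number of the set; its nearest neighbour is compound 1, a 2.8-fold lower number from compound 1 to compound 3 (0.45 log units; beyond the scatter), and its furthest is compound 2, an 8.5-fold lower number from compound 2 to compound 3 (0.93 log units; beyond the scatter). Both steps lie beyond the scatter, so on these numbers compound 3 stands as the most potent of the three.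

Compound 4 `C/C=C/C(=O)N(Cc1ccc(OC)c(O)c1)c1cc(OC)c(OC)c(OC)c1` is the next member. Its difference from compound 3 is prop-1-en-1-yl in place of ethyl on a carbonyl carbon. The change keeps the acyl group on the carbonyl carbon bound to the amide-type nitrogen and moves from propanoyl to (prop-1-en-1-yl)carbonyl. The measured steps that bear on it are those along the same chain: a 2.8-fold lower number from compound 1 to compound 3 (0.45 log units; beyond the scatter), where ethyl gave way to hydrogen and the number fell, and an 8.5-fold lower number from compound 2 to compound 3 (0.93 log units; beyond the scatter), where hydroxy gave way to methyl and the number fell more. Neither covers a double bond, which leaves the outcome uncertain. A modest rise in number is expected for compound 4 because a 2.8-fold lower number from compound 1 to compound 3 (0.45 log units; beyond the scatter) ran the other way when the chain was shortened, and the step of a 1.6-fold higher number from compound 3 to compound 4 (0.21 log units; within the scatter) is therefore expected to be small and possibly within the scatter. Compound 4 is estimated at 100 nM, with a range of 45 nM to 230 nM.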

Compound 4, half-maximal inhibitory concentration: 55 nM
Estimate against measurement, compound 4: 1.8-fold (0.26 log units) above; measured number inside the range.
By their numbers in this assay, from the lowest: compounds 4 and 3 (each within the scatter of the next); then compound 1; then compound 2.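

In this assay the double bond is the new feature on this carbonyl carbon, and a 1.1-fold lower number from compound 3 to compound 4 (0.04 log units; within the scatter) leaves prop-1-en-1-yl and ethyl within the scatter of each other, so this position accepts the larger, unsaturated group with no readable difference in the number. The same group also separates clearly from the other two acyl groups, with a 3.1-fold lower number from compound 1 to compound 4 (0.49 log units; beyond the scatter) in place of butyl and a 9.5-fold lower number from compound 2 to compound 4 (0.98 log units; beyond the scatter) in place of hydroxymethyl, both beyond the scatter, which places compound 3 and compound 4 together at the low end of these four numbers. No measured evidence is available here to explain any of these steps.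

The compounds shown leave open whether the double bond itself contributes anything, since a propyl group on the carbonyl carbon would be the comparison that separates it from chain length. On these data alone, how an amine or a carboxylic acid at the end of the acyl chain would read in this assay also remains open, as hydroxymethyl is the only heteroatom-bearing acyl substituent in this set.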